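Triazole aryl swap and GES1 cytotoxicity, compound 3

A few compounds are considered here, and "the series" means these few. Any claim that something is new, unique, unknown or untested is made for them only; others in the source may bear on it.

Among the compounds with values here, compound 2 `Cc1cccc(-n2cc(-c3ccccc3NS(=O)(=O)c3c[nH]c(=O)[nH]c3=O)nn2)c1` carries the only plain number on an ADME assay on GES1 cells (Homo sapiens) for cytotoxicity, read by MTT assay, with a stated time of 24 h (on this read-out higher numbers stand for lower toxicity in this test and lower numbers for higher toxicity in this test), where compound 2 gives 23700 nM. Compound 1 `O=c1[nH]cc(S(=O)(=O)Nc2ccccc2-c2cn(-c3ccccc3)nn2)c(=O)[nH]1` returns a limit of the test rather than a number, > 100000 nM, the limit recorded in the limit of > 100000 nM in this assay, at which 1 of the 2 values shown sits. Within the data shown here, the single step that joins them, methyl in place of hydrogen on an aromatic carbon, is an at least 4.2-fold lower number from compound 1 to compound 2 (0.62 log units; beyond the scatter), so the methyl-bearing compound 2 is the more toxic of the two.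

Compound 3 `O=c1[nH]cc(S(=O)(=O)Nc2ccccc2-c2cn(-c3ccccc3F)nn2)c(=O)[nH]1` differs from compound 2 by 2-fluorophenyl in place of 3-methylphenyl on an aromatic nitrogen. Among the measured compounds shown here, only the step from compound 1 to compound 2 bears on this change, and it was at least modest toward a lower number when the methyl entered; compound 3 removes that methyl and brings in a fluorine-bearing ring, for which no direct comparison exists. The expectation is therefore a move back toward the limit seen for compound 1, of uncertain size, with a 2.1-fold higher number from compound 2 to compound 3 (0.32 log units; beyond the scatter) expected on this assay. Compound 3 is estimated at 50000 nM, within a range of 15000 nM to 150000 nM, and the read-out may again stop at the limit.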

Compound 3, half-maximal cytotoxic concentration: > 100000 nM
Compound 3 ended at the assay's limit (the forecaster's own chance of this, stated with the estimate: 40%); middle value at least 2.0-fold (0.30 log units) away from the limit.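

On the aromatic nitrogen of the five-membered ring, 2-fluorophenyl in place of 3-methylphenyl gives an at least 4.2-fold higher number from compound 2 to compound 3 (0.62 log units; beyond the scatter) in this assay, so the lower number seen for compound 2 does not carry over to this fluorine-bearing ring. Of the three aryl groups shown at this position, only the 3-methylphenyl of compound 2 gives a plain number, which marks that group, and not substitution of the phenyl ring as such, as the change linked to higher toxicity in this test. The step between compound 1 and compound 3 cannot be read, and the phenyl and 2-fluorophenyl groups cannot be ranked, because both values are limits of the test and not numbers: the limit of > 100000 nM in this assay, at which 2 of the 3 values shown sit.

Going by these compounds, how far compound 1 and compound 3 lie beyond that limit stays open, as does whether the lower number of compound 2 follows from the methyl group itself or from where it sits on the ring. Also open, on these data alone, is how this assay responds when a methoxy group, an amine or a carboxylic acid stands on the phenyl ring at this position.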